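Replacing a methyl ether with an oxolanyl ether

A few compounds are considered here, and "the series" means these few. Any claim that something is new, unique, unknown or untested is made for them only; others in the source may bear on it.

In a functional assay on PC-3 cells (Homo sapiens) for antiproliferative activity, read by MTT assay, with a stated time of 72 h (a lower number here means a stronger inhibitor, a higher number a weaker inhibitor), compound 1 `CC/C=C/C(=O)Nc1cc2c(N3CCc4ccccc43)ncnc2cc1OC` gives 5890 nM, and compound 2 `CCC/C=C/C(=O)Nc1cc2c(N3CCc4ccccc43)ncnc2cc1OC` gives 4240 nM. The step of a 1.4-fold lower number from compound 1 to compound 2 (0.14 log units; within the scatter) stays within the scatter, so the two numbers cannot be told apart. For the measured compounds named here, compound 2 holds the lower of the two numbers, with compound 1 as its only neighbour at a separation within the scatter.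

Compound 3 `CCC/C=C/C(=O)Nc1cc2c(N3CCc4ccccc43)ncnc2cc1O[C@@H]1CCOC1` differs from compound 2 in one place: oxolan-3-yl in place of methyl on an oxygen on an aromatic ring. Going by the values given here, the single measured step, from compound 1 to compound 2, alters the saturated chain and leaves the ether on the aromatic ring untouched, so no measured step bears directly on this change. Nothing in the measured pair points one way or the other for the ether. The number expected for compound 3 in this assay is therefore one near that of compound 2, and the expected step is a 1.3-fold lower number from compound 2 to compound 3 (0.12 log units; within the scatter), kept within the scatter. The estimate for compound 3 in this assay is 3200 nM, with a range from 900 nM to 11000 nM.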

Compound 3, half-maximal inhibitory concentration: 9230 nM
Compound 3: the middle estimate sits 2.9-fold (0.46 log units) below what was measured; measured number inside the range.
By their numbers in this assay, from the lowest: compounds 2, 1 and 3 (each within the scatter of the next, the first and the last beyond it).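

In this assay the ether on the aromatic ring gives a readable change: oxolan-3-yl in place of methyl on this oxygen produces a 2.2-fold higher number from compound 2 to compound 3 (0.34 log units; beyond the scatter) and thus a modest loss of inhibition, whereas the change in the saturated chain, a 1.4-fold lower number from compound 1 to compound 2 (0.14 log units; within the scatter) in the same assay, could not be told apart from repeat scatter. For the compounds shown here, this is the first sign that the group on this oxygen matters to the number, and that the methoxy of compound 2 cannot be swapped for the larger (oxolan-3-yl)oxy group at no cost. The change brings in a five-membered non-aromatic ring, a hydrogen-bond acceptor and a defined stereocentre all at once, and no evidence is available to separate these or to explain the direction of the step.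

The compounds shown leave open whether the opposite stereocentre of the oxolan-3-yl group would give a similar number, and whether the same step would appear on the shorter chain of compound 1. They also leave open how a plain ethyl or a 2-methoxyethyl group on this oxygen would read, which would show whether the ring itself is tied to the higher number.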